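A few compounds are considered here, and "the series" means these few. Any claim that something is new, unique, unknown or untested is made for them only; others in the source may bear on it.

Compound 2 `CCOC(=O)CCCCCOc1cccc(CN(C(=O)c2ccc(-c3ccco3)cc2)C(C)C)c1` was tested in an ADME assay on Raji cells (Homo sapiens) for cytotoxicity, read by CellTiter-Glo and resazurin assay, with a stated time of 72 h; on this read-out higher numbers stand for an effect only at larger amounts of compound and lower numbers for an effect already at smaller amounts. In this assay compound 2 gives > 26000 nM, which is a limit of the assay and not a number. Compound 1 `CCOC(=O)CCCCCOc1cccc(CN(C(=O)c2ccc(-c3cccc(OC(C)C)c3)cc2)C(C)C)c1` differs from it by carrying 3-isopropoxyphenyl where compound 2 carries furan-2-yl. In this assay compound 1 gives > 26000 nM, again a limit rather than a number. The step that the two limits leave unreadable from compound 1 to compound 2 therefore cannot be read, since both ends sit at the limit of > 26000 nM in this assay, at which 2 of the 2 values shown sit. Compound 3 `CCOC(=O)CCCCCOc1cccc(CN(C(=O)c2ccc(-c3cccc(-c4nnc(C)o4)c3)cc2)C(C)C)c1` has not yet been measured. It differs from compound 2 in one place: 3-(5-methyl-1,3,4-oxadiazol-2-yl)phenyl in place of furan-2-yl on an aromatic carbon. For the measured compounds named here, the only measured step, from compound 1 to compound 2, is unreadable, so no measured step gives a size for this change; both measured compounds show an effect, if any, only beyond the limit of this assay. The expectation is that compound 3 likewise shows no effect up to that limit, a step of a number no higher from compound 2 to compound 3 (the limit leaves the size open) that stays within the scatter. Compound 3 is thus expected to give about 26000 nM in this assay, with a range from 13000 nM to 52000 nM, most likely again reported as a limit.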

Compound 3, half-maximal effective concentration: > 26000 nM
Compound 3 gave a limit, no number; the forecaster's own chance of this, stated with the estimate: 80%; the middle value lies on the limit itself.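

Compound 1, compound 2 and compound 3 all end at a limit and not at a number in this assay, so no step among them can be read: the limit of > 26000 nM in this assay, at which 3 of the 3 values shown sit.

The compounds shown leave open whether any of them has an effect on these cells, and how far furan-2-yl, 3-isopropoxyphenyl and 3-(5-methyl-1,3,4-oxadiazol-2-yl)phenyl differ.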